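Replacing the 3-nitrophenyl group of compound 2

The source may hold more compounds than are shown below. What is called first, only, known or untested is meant among the compounds shown, and "the series" means these compounds.

Of the compounds shown here, three have been measured so far in a physicochemical assay for lipophilicity, measured as octanol-water partition (a lower number here means a more polar compound, a higher number a more lipophilic compound), and they spread widely. Compound 1 `CCOc1ccc(/C=N/NC(=O)COc2cccc3ccccc23)cc1O` gives 3.82 here, compound 2 `C/C(=N\NC(=O)COc1cccc2ccccc12)c1cccc([N+](=O)[O-])c1` gives 3.37 and compound 3 `O=C(COc1cccc2ccccc12)N/N=C/C=C/c1ccccc1` gives 4.43 as the top figure. Compound 2 is the lowest of the three, with both others higher by more than the usual scatter. Compound 4 `C/C(=N\NC(=O)COc1cccc2ccccc12)c1ccc(O)cc1O` is still unmeasured. It differs from compound 2 in one place (2,4-dihydroxyphenyl in place of 3-nitrophenyl on a carbon with a double bond to nitrogen): 2,4-dihydroxyphenyl in place of 3-nitrophenyl on a carbon with a double bond to nitrogen. Among the compounds with values here, no measured pair shows such a swap, so the expectation is rough: a drop in this assay somewhat beyond the scatter. The expected change is a number 0.37 log units lower from compound 2 to compound 4 (beyond the scatter) in this estimate. Compound 4 is expected at 3 with an estimated range (2.5 to 3.5).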

Compound 4, partition coefficient: 4.31
Compound 4: middle estimate off by 1.31 log units, on the low side; measured number outside the range, above it.
By their numbers in this assay, from the lowest: compound 2; then compound 1; then compounds 4 and 3 (each within the scatter of the next).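

On a carbon with a double bond to nitrogen, 2,4-dihydroxyphenyl in place of 3-nitrophenyl gives a number 0.94 log units higher from compound 2 to compound 4 (beyond the scatter) in this assay, so this position can shift the number substantially. The entering group carries hydrogen-bond donors that the leaving group lacks, yet the number rises, so the donor count alone does not set the number in this pair. No measurement shown here accounts for the rise.

This single swap shows no trend at the position. Going by these compounds, how a phenyl bearing one hydroxyl, an amine or a carboxylic acid would read remains open.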